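Methoxy Added Next to the Hydroxy Group of Compound 2

The compounds below may be only part of what the source reports. "The series", "measured", "known", "first", "only" and "open" are said of these compounds alone.

Of the compounds shown here, three have been measured so far, all built on one shared core. Compound 1 `COc1ccc(-c2nc(-c3c[nH]c4ccccc34)co2)cc1OC` carries two methoxy groups on its outer ring, compound 2 `Oc1ccc(-c2nc(-c3c[nH]c4ccccc34)co2)cc1` carries a single hydroxy group there, and compound 3 `c1ccc2c(-c3cocn3)c[nH]c2c1` lacks that outer ring altogether. In a functional assay on PC-3 cells (Homo sapiens) for cytotoxicity, read by MTT assay, with a stated time of 48 h (on this read-out lower numbers stand for stronger inhibition and higher numbers for weaker inhibition), compound 2 gives 382000 nM; in this assay compound 1 gives 359000 nM and compound 3 gives 321000 nM, so all three numbers sit within the usual scatter of one another and none can be called stronger or weaker than the others.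

Compound 4 `COc1cc(-c2nc(-c3c[nH]c4ccccc34)co2)ccc1O` differs from compound 2 by methoxy in place of hydrogen on an aromatic carbon. The new group sits on an aromatic carbon of a six-membered aromatic ring of carbon only, ortho to a hydroxy group and meta to a large group.

For the measured compounds named here, the one measured step that bears on this change is a 1.2-fold lower number from compound 2 to compound 3 (0.08 log units; within the scatter): even removing the whole 4-hydroxyphenyl group left the number essentially unchanged. Since so large a removal did nothing beyond the scatter, adding a methoxy group is expected to do no more, and the step of a 1.0-fold lower number from compound 2 to compound 4 (0.01 log units; within the scatter) is expected to stay within the scatter.

Compound 4 is therefore estimated at 370000 nM, within a range from 200000 nM to 700000 nM.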

Compound 4, half-maximal inhibitory concentration: 303000 nM
The estimate for compound 4 lay 1.2-fold (0.09 log units) above the measured number, within the range that was stated.
By their numbers in this assay, from the lowest: compounds 4, 3, 1 and 2 (each within the scatter of the next).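

In this assay, methoxy in place of hydrogen on an aromatic carbon, ortho to a hydroxy group, gives a 1.3-fold lower number from compound 2 to compound 4 (0.10 log units; within the scatter), so adding a small group at this position leaves the number as unmoved as removing the whole 4-hydroxyphenyl group did. The second step, with hydrogen in place of methyl on an oxygen on an aromatic ring, gives a 1.2-fold lower number from compound 1 to compound 4 (0.07 log units; within the scatter), so swapping between methyl and hydrogen on that oxygen also stays within the scatter, and a hydroxy group and a methoxy group cannot be told apart by this read-out. Nothing measured on these compounds explains why these changes make so little difference.

From the compounds shown here alone, the outer ring has so far carried only hydroxy and methoxy groups, so it remains open whether an amine, a carboxylic acid or a longer chain at this position would move the number beyond the scatter. Also open, going by these compounds, is whether a change elsewhere on the shared core would separate any compound from the others in this assay.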